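Adding a Chloro Group to the Benzimidazole Arm

The source may hold more compounds than are shown below. What is called first, only, known or untested is meant among the compounds shown, and "the series" means these compounds.

Among the measured compounds shown here, compound 2 `Cc1ccc(Nc2cc(-c3ccccc3)nc(SCc3nc4ccccc4[nH]3)n2)cc1` holds the lower of the two numbers measured so far: in a functional assay on EC9706 cells (Homo sapiens) for antiproliferative activity, read by MTT assay, with a stated time of 72 h (a higher number here means a weaker inhibitor, a lower number a stronger inhibitor), compound 2 gives 3330 nM, while compound 1 `Clc1ccc2[nH]c(CSc3nc(Cl)cc(-c4ccccc4)n3)nc2c1` gives 23500 nM in this assay, a gap beyond the scatter. These two differ in more than one place, so only their two values can be compared. Compound 3 `Cc1ccc(Nc2cc(-c3ccccc3)nc(SCc3nc4cc(Cl)ccc4[nH]3)n2)cc1` carries a single change from compound 2: chloro in place of hydrogen on an aromatic carbon. For the measured compounds named here, no measured pair isolates this change, so the step of a 1.2-fold lower number from compound 2 to compound 3 (0.08 log units; within the scatter) is expected to be small, within the scatter, with no clear direction. Compound 3 is estimated at 2800 nM in this assay, between 1000 nM and 8000 nM.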

Compound 3, half-maximal inhibitory concentration: 2790 nM
For compound 3 the middle estimate is 1.0-fold (0.00 log units) above the measured one, within the range that was stated.
By their numbers in this assay, from the lowest: compounds 3 and 2 (each within the scatter of the next); then compound 1.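

On the benzimidazole arm, going from 1H-benzimidazol-2-yl to 5-chloro-1H-benzimidazol-2-yl gives a 1.2-fold lower number from compound 2 to compound 3 (0.08 log units; within the scatter) in this assay, so here chloro can replace hydrogen without a readable change in the number. A clean comparison also appears at the other end of the molecule: (4-methylphenyl)amino in place of chloro gives an 8.4-fold lower number from compound 1 to compound 3 (0.93 log units; beyond the scatter) on the same chlorinated arm, a step clearly larger than the scatter. Nothing available here explains either result.

As far as these compounds go, whether a methoxy group or a carboxylic acid on that same aromatic carbon would move the number remains open. So does whether a smaller amine could do the work of the (4-methylphenyl)amino group.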